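A Fluorine Added to the Second Phenyl Ring

The source may report more compounds than this note shows. Statements on the series, on what has been measured and on what is new or still open speak of the compounds shown alone.

Compound 1 `O=C1CSC(N2N=C(c3ccc(Cl)c(Cl)c3)CC2c2ccccc2)=N1` is the starting point of this small set; in an ADME assay on RAW264.7 cells (Mus musculus) for cytotoxicity, read by MTT assay, with a stated time of 24 h (on this read-out higher numbers stand for lower toxicity in this test and lower numbers for higher toxicity in this test), compound 1 gives 295000 nM. Compound 3 `O=C1CSC(N2N=C(c3ccc(Cl)c(Cl)c3)CC2c2ccccc2Cl)=N1` adds one chlorine to it, and in this assay compound 3 gives 143000 nM, a change of a 2.1-fold lower number from compound 1 to compound 3 (0.31 log units; beyond the scatter). Compound 2 `Cc1ccc(C2=NN(C3=NC(=O)CS3)C(c3ccccc3)C2)cc1C` instead carries a 3,4-dimethylphenyl in place of the 3,4-dichlorophenyl. For compound 2 the result in this assay is a limit of the assay and not a measured number: > 450000 nM. Compound 2 thus sits at the limit of > 450000 nM in this assay, at which 1 of the 3 values shown sits, so only a floor is known for it, and the step of an at least 1.5-fold higher number from compound 1 to compound 2 (0.18 log units; that floor lies within the scatter) is likewise only a floor.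

Compound 4 `Cc1ccc(C2=NN(C3=NC(=O)CS3)C(c3ccc(F)cc3)C2)cc1C` differs from compound 2 by a single atom: fluoro in place of hydrogen on an aromatic carbon. Going by the values given here, the only measured step of the same kind, a halogen placed on an aromatic carbon, is a 2.1-fold lower number from compound 1 to compound 3 (0.31 log units; beyond the scatter), but that used chlorine on a different ring, and fluorine is smaller. Among the compounds with values here, the expectation is therefore for a change no larger than the scatter, most likely no step at all beyond it, which as an at least 1.1-fold lower number from compound 2 to compound 4 (0.05 log units; that floor lies within the scatter) is an estimate rather than a result. Compound 4 is accordingly estimated at 400000 nM, with a likely range from 200000 nM to 800000 nM, and a fair chance that the assay again reports only a limit.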

Compound 4, half-maximal cytotoxic concentration: 246000 nM
Beside the measured number, compound 4's estimate is 1.6-fold (0.21 log units) above it; the range from low to high includes it.
By their numbers in this assay, from the lowest: compounds 3, 4 and 1 (each within the scatter of the next, the first and the last beyond it). At a limit, above all of these: compound 2.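

Fluoro on this aromatic carbon, para to a large group, gives the 3,4-dimethylphenyl series a compound with a real measured number in this assay, which compound 2 could not supply. The change from phenyl to 4-fluorophenyl reads as an at least 1.8-fold lower number from compound 2 to compound 4 (0.26 log units; that floor lies within the scatter); this figure is only a floor, so the true step could be larger, but its size cannot be read from these data, and a step within the scatter cannot be ruled out. Compound 2 is known only through a limit of the assay: the limit of > 450000 nM in this assay, at which 1 of the 4 values shown sits.

The compounds shown leave open whether fluoro would give a comparable step on the 3,4-dichlorophenyl background of compound 1, since no pair here tests the same change on both backgrounds. They also leave open what other groups on this same aromatic carbon would do, such as a methoxy, an amine or a carboxylic acid, and whether a chloro there would read differently from the fluoro of compound 4.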